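The source may hold more compounds than are shown below. What is called first, only, known or untested is meant among the compounds shown, and "the series" means these compounds.

Measured compounds:
compound 1 `COC(=O)[C@@]1(C)CC[C@@H]2C3=C1CC[C@@H](C)[C@]3(C)C[C@@H]1c3ccccc3N[C@H]21` with 30000 nM in a functional assay on SW1573 cells (Homo sapiens) for inhibition, read by sulforhodamine B assay, with a stated time of 48 h; on this read-out lower numbers stand for stronger inhibition of growth and higher numbers for weaker inhibition of growth
compound 2 `COC(=O)[C@@]1(C)CC[C@@H]2C3=C1CC[C@@H](C)[C@]3(C)C[C@@H]1c3cc(F)ccc3N[C@H]21` with 27000 nM in this assay

Among the measured compounds shown here, compound 1 gives the highest of the two numbers measured so far; compound 2 is its nearest neighbour, and a 1.1-fold lower number from compound 1 to compound 2 (0.05 log units; within the scatter) lies within the scatter. Compound 3 `COC(=O)[C@@]1(C)CC[C@@H]2C3=C1CC[C@@H](C)[C@]3(C)C[C@@H]1c3cccc(C)c3N[C@H]21` differs from compound 1 by methyl in place of hydrogen on an aromatic carbon. For the measured compounds named here, the only step that bears on this change is the fluoro substitution, a 1.1-fold lower number from compound 1 to compound 2 (0.05 log units; within the scatter), which produced no shift beyond the scatter. A step of similar size in this assay is therefore expected for a 1.1-fold lower number from compound 1 to compound 3 (0.03 log units; within the scatter). Compound 3 is estimated at 28000 nM, with a range from 14000 nM to 56000 nM.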

Compound 3, concentration for 50% growth inhibition: 31000 nM
Beside the measured number, compound 3's estimate is 1.1-fold (0.04 log units) below it, within the range that was stated.
By their numbers in this assay, from the lowest: compounds 2, 1 and 3 (each within the scatter of the next).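

Methyl in place of hydrogen on this aromatic carbon, ortho to a fused ring and meta to a fused ring, gives a 1.0-fold higher number from compound 1 to compound 3 (0.01 log units; within the scatter) in this assay. This is the first carbon group on that ring among the compounds shown, and it shows that adding one heavy atom at this position leaves compound 3 within the scatter of compound 1. Nothing measured here offers an explanation for this result.

From the compounds shown here alone, whether an amine, a carboxylic acid or a longer chain at this position would give a step beyond the scatter remains open.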